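This account rests on a few compounds, and the source may have more. Where it says the series, first, only, none or still open, it means among the compounds named here.

Measured compounds in the series:

- compound 1, `COc1nc(N)nc2c1c(-c1cc3ccccc3o1)cn2[C@@H]1O[C@H](CO)[C@@H](O)[C@H]1O`: 25600 nM
- compound 2, `C#Cc1cn([C@@H]2O[C@H](CO)[C@@H](O)[C@H]2O)c2ncnc(OC)c12`: 98400 nM
- compound 3, `Nc1nc2c(c(-c3ccccc3)cn2[C@@H]2O[C@H](CO)[C@@H](O)[C@H]2O)c(=O)[nH]1`: > 100000 nM

In an ADME assay on BJ cells (Homo sapiens), read by MTT assay, with a stated time of 72 h (a higher number here means a weaker inhibitor, a lower number a stronger inhibitor), compound 2 gives 98400 nM, the higher of the two numbers obtained. In this assay compound 1 gives 25600 nM, and the gap from compound 1 to compound 2 lies beyond the usual scatter, so compound 2 is the weaker inhibitor of the two. For compound 3 this assay reports only a limit, > 100000 nM, not a number; this is the limit described as the limit of > 100000 nM in this assay, at which 1 of the 3 values shown sits, and no ordering against the other two follows from it.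

Compound 4, `COc1ncnc2c1c(-c1cccs1)cn2[C@@H]1O[C@H](CO)[C@@H](O)[C@H]1O`, has not been measured in this assay. It is derived from compound 2 by a single change: thiophen-2-yl in place of ethynyl on an aromatic carbon. Going by the values given here, no step between two measured compounds isolates this change, so the expected size of the step rests only on the values of compound 1 and compound 2, which share the sugar and the fused core but differ in more than one place. Compound 4 is expected to give a somewhat lower number than compound 2, with the step from compound 2 to compound 4 estimated at a 2.5-fold lower number from compound 2 to compound 4 (0.39 log units; beyond the scatter). The estimate for compound 4 in this assay is 40000 nM, within the range 10000 nM to 150000 nM.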

Compound 4, half-maximal inhibitory concentration: 62800 nM
Compound 4: middle estimate off by 1.6-fold (0.20 log units), on the low side; the measured number falls inside the stated range.
By their numbers in this assay, from the lowest: compound 1; then compounds 4 and 2 (each within the scatter of the next). At a limit, above all of these: compound 3.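

In this assay, going by these compounds alone, thiophen-2-yl in place of ethynyl on this aromatic carbon gives a 1.6-fold lower number from compound 2 to compound 4 (0.20 log units; within the scatter), the first step that isolates a single change. At this position, therefore, a five-membered aromatic ring with one sulfur can replace a triple bond outside aromatic rings without a shift beyond the usual scatter, so the two groups are not separated by this read-out; the gap between compound 1 and compound 2 cannot be assigned to this position alone, since those compounds differ in more than one place. Nothing measured here gives a cause for this step.

Still open, as far as these compounds go, is whether any group on this aromatic carbon moves the number beyond the scatter, for instance an amine, a carboxylic acid or a longer alkyl chain, any of which would test the position with a group unlike both ethynyl and thiophen-2-yl. Also open, from the compounds shown here alone, is whether the same exchange gives a comparable step on the core of compound 1, which carries a different substitution pattern from compound 2 and compound 4.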